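Para substituent of the benzoate ester: methyl, hydrogen, trifluoromethyl

The compounds below may be only part of what the source reports. "The series", "measured", "known", "first", "only" and "open" are said of these compounds alone.

Compound 1 `CC1=CC[C@H](C(C)C)c2cc(C)c(OC(=O)c3ccc(C)cc3)cc21` gives 78.9% in a functional assay on HCT-15 cells (Homo sapiens) for antiproliferative activity, read by sulforhodamine B assay, with a stated time of 48 h, tested at 50 uM; a lower number here means less inhibition, a higher number more inhibition at the concentration tested (going by the name of the read-out). Compound 2 `CC1=CC[C@H](C(C)C)c2cc(C)c(OC(=O)c3ccccc3)cc21` gives 49.5%, the lowest of the two numbers; the change was a number 29.4 percentage points lower from compound 1 to compound 2 (beyond the scatter). Compound 3 `CC1=CC[C@H](C(C)C)c2cc(C)c(OC(=O)c3ccc(C(F)(F)F)cc3)cc21` carries trifluoromethyl in place of hydrogen on an aromatic carbon. For the measured compounds named here, only the step from compound 1 to compound 2 bears on this, and it shows a modest loss when the methyl is removed; restoring a group at that aromatic carbon is expected to recover some inhibition, though the size is uncertain. The expected step is a number 18.5 percentage points higher from compound 2 to compound 3 (beyond the scatter). Compound 3 is therefore estimated at 68%, within 45% to 90%.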

Compound 3, a percentage reported as inhibition, at one concentration (the size of the read-out at that concentration, not a potency): 6.4%
Beside the measured number, compound 3's estimate is 61.6 percentage points above it; measured number below the stated range.
By their numbers in this assay, from the lowest: compound 3; then compound 2; then compound 1.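

In this assay, trifluoromethyl on this aromatic carbon gives a number 43.1 percentage points lower from compound 2 to compound 3 (beyond the scatter) and, set against methyl, a number 72.5 percentage points lower from compound 1 to compound 3 (beyond the scatter). Replacing hydrogen at this position therefore does not raise inhibition as a general rule: relative to compound 2, methyl and trifluoromethyl move the read-out in opposite directions. Nothing available explains why these two groups diverge. For the compounds shown here, with only three groups compared, it remains open how methoxy, chlorine or an amine on this carbon would rank against methyl and trifluoromethyl.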